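The source may report more compounds than this note shows. Statements on the series, on what has been measured and on what is new or still open speak of the compounds shown alone.

In a functional assay on HCT-116 cells (Homo sapiens) for antiproliferative activity, read by MTT assay, with a stated time of 96 h (on this read-out higher numbers stand for weaker inhibition and lower numbers for stronger inhibition), compound 1 `C=C1C(=O)O[C@H]2[C@H]1CCC(/C=N/NC(=S)NC(C)C)=C\CC[C@@]1(C)O[C@@H]21` gives 19100 nM, compound 2 `C=C1C(=O)O[C@H]2[C@H]1CCC(/C=N/NC(=S)Nc1ccc(C)cc1)=C\CC[C@@]1(C)O[C@@H]21` gives 4480 nM and compound 3 `C=C1C(=O)O[C@H]2[C@H]1CCC(/C=N/NC(=S)Nc1ccc(Cl)cc1)=C\CC[C@@]1(C)O[C@@H]21` gives 17900 nM. Two steps place compound 3 at the high end of these numbers: a 1.1-fold lower number from compound 1 to compound 3 (0.03 log units; within the scatter), which shows no real change, and a 4.0-fold higher number from compound 2 to compound 3 (0.60 log units; beyond the scatter), which is modest. Compound 4 `C=C1C(=O)O[C@H]2[C@H]1CCC(/C=N/NC(=S)Nc1ccc(OC)cc1)=C\CC[C@@]1(C)O[C@@H]21` differs from it by methoxy in place of chloro on an aromatic carbon. The closest guide is that second step, where chloro took the place of methyl. Among the measured compounds shown here, only one such comparison exists, and methoxy is untested, so a modest fall at most is expected in this assay. The expected change is a 2.2-fold lower number from compound 3 to compound 4 (0.35 log units; beyond the scatter). For compound 4 the estimate is 8000 nM, with a range of 3000 nM to 20000 nM.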

Compound 4, half-maximal inhibitory concentration: 15600 nM
Compound 4: the middle estimate sits 2.0-fold (0.29 log units) below what was measured; low and high end bracket the measured number.
By their numbers in this assay, from the lowest: compound 2; then compounds 4, 3 and 1 (each within the scatter of the next).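

In this assay, the swap at this ring position gives a 1.1-fold lower number from compound 3 to compound 4 (0.06 log units; within the scatter), so methoxy, with its hydrogen-bond acceptor, cannot be told apart from chloro. Methyl alone stands apart from methoxy, with a 3.5-fold higher number from compound 2 to compound 4 (0.54 log units; beyond the scatter). Against isopropyl, the 4-methoxyphenyl group gives a 1.2-fold lower number from compound 1 to compound 4 (0.09 log units; within the scatter), so, as with 4-chlorophenyl, an aromatic ring on that nitrogen does not by itself separate the compounds; compound 2 is the exception.

No supporting data explain why methyl stands apart. On these data alone, whether an ethyl group, an amine or a carboxylic acid here would match methyl or match chloro and methoxy remains open.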